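The source may report more compounds than this note shows. Statements on the series, on what has been measured and on what is new or still open speak of the compounds shown alone.

Working notes on the series. Compound 1 `CCCCCCCCCCCCO/N=C/c1cc(OC)c2c(c1OC)C(=O)C=CC2=O` has been tested in a functional assay on A549 cells (Homo sapiens) for antiproliferative activity; a lower number here means that less compound is needed, a higher number that more compound is needed for the effect. In that assay compound 1 gives > 10 ug/mL, which is a limit of the assay and not a number. For the measured compounds named here, compound 2 `CCCCCC/C(=N\OCCCCC)c1cc(OC)c2c(c1OC)C(=O)C=CC2=O` is the only other measured member of the series. In this assay compound 2 gives > 10 ug/mL, again a limit rather than a number. Both shown values therefore sit at the limit of > 10 ug/mL in this assay, at which 2 of the 2 values shown sit, no measured step between compounds is available, and where compound 1 stands beyond that limit is unknown.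

Compound 3 `CCCCCCCO/N=C/c1cc(OC)c2c(c1OC)C(=O)C=CC2=O` is not yet measured. It differs from compound 1 by hydrogen in place of pentyl on a saturated chain carbon, seven bonds along the chain from an oxygen on an unsaturated carbon. Since both shown values sit at the limit of > 10 ug/mL in this assay, at which 2 of the 2 values shown sit, the expected step is a step that the limit leaves unreadable from compound 1 to compound 3, none beyond the usual scatter. For compound 3 the expected value in this assay is 15 ug/mL, with a range from 5 ug/mL to 50 ug/mL, most probably reported once more only as a limit.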

Compound 3, concentration for half-maximal effect: > 10 ug/mL
Compound 3: a limit, no number; the forecaster's own chance of this, stated with the estimate: 75%; the middle value does not contradict the limit.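

In this assay compound 3 gives > 10 ug/mL as a limit and not a number. For the compounds shown here, no step between compound 1 and compound 3 can be read: the limit of > 10 ug/mL in this assay, at which 3 of the 3 values shown sit. The compounds shown leave open whether any of them reaches a measurable value and how chain length bears on it.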